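The source may hold more compounds than are shown below. What is called first, only, known or untested is meant among the compounds shown, and "the series" means these compounds.

The measured compounds:
compound 1 `COc1cc2cc[nH]c2cc1-c1ccncc1` gives 3600 nM
compound 2 `COc1cc2c(C(=O)N3CCN(C)CC3)n[nH]c2cc1-c1ccncc1` gives 31 nM
compound 3 `COc1cc2c(C(=O)N3CCN(C)CC3)n[nH]c2cc1-c1cc(C)nc(C)c1` gives 2.5 nM

All three numbers come from an assay on PBMC cells for antagonist activity at Toll-like receptor 8 (Homo sapiens), with stated times of 30 min and 20 h; a lower number here means a stronger inhibitor, a higher number a weaker inhibitor. Compound 3 stands at the lowest number of the three. Its nearest neighbour is compound 2, separated by the step of a 12-fold lower number from compound 2 to compound 3 (1.09 log units; beyond the scatter), which lies beyond the scatter; compound 1, which lacks the amide-bearing part of the shared core, gives a far higher number still.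

Compound 4 `COc1cc2c(C(=O)N3CCN(C)CC3)n[nH]c2cc1-c1ccnc(C)c1F` has not yet been measured in this assay. Compared with compound 3, the change is: a group of 8 heavy atoms (6 carbon, 1 nitrogen, 1 fluorine; one six-membered aromatic ring with 1 hetero atom) in place of a group of 8 heavy atoms (7 carbon, 1 nitrogen; one six-membered aromatic ring with 1 hetero atom), on an aromatic carbon. Among the compounds with values here, only one measured step bears on this: a 12-fold lower number from compound 2 to compound 3 (1.09 log units; beyond the scatter), where the two methyl groups added to the pyridine ring brought a large gain. Compound 4 keeps one of those methyl groups and carries a fluorine in place of the other, so it does not go all the way back to the pyridin-4-yl of compound 2. A small rise in the number is therefore expected, a 2.4-fold higher number from compound 3 to compound 4 (0.38 log units; beyond the scatter), most likely within or just beyond the scatter. For compound 4 the estimate in this assay is 6 nM, with a range from 2 nM to 20 nM.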

Compound 4, half-maximal inhibitory concentration: 1.2 nM
For compound 4 the middle estimate is 5.0-fold (0.70 log units) above the measured one; measured number outside the range, below it.
By their numbers in this assay, from the lowest: compound 4; then compound 3; then compound 2; then compound 1.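

In this assay the result shows that two methyl groups are not needed on the pyridine ring at this aromatic carbon: a ring carrying one methyl and one fluorine in place of 2,6-dimethylpyridin-4-yl gives a 2.1-fold lower number from compound 3 to compound 4 (0.32 log units; beyond the scatter) and so goes further down, not back up. Set against the unsubstituted pyridin-4-yl, the same ring gives a 26-fold lower number from compound 2 to compound 4 (1.41 log units; beyond the scatter) and so exceeds the gain that the two methyl groups brought. Nothing available here explains why this ring gives the lowest number of the four.

The compounds shown leave open how much the fluorine and the remaining methyl each contribute, as the two appear only together. Also open, going by these compounds, is whether a chlorine or a trifluoromethyl group in the place of the fluorine would lower the number further or raise it.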